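This account rests on a few compounds, and the source may have more. Where it says the series, first, only, none or still open, it means among the compounds named here.

Working notes on the series. The parent ester, compound 1 `C#CCOC(=O)/C(C)=C/CC/C(C)=C/CC/C(C)=C/CC[C@@H]1[C@@]2(C)CCC(=O)C(C)(C)[C@H]2CC[C@@]1(C)O`, carries a prop-2-ynyl ester on the shared core; in a functional assay on DU-145 cells (Homo sapiens) for antiproliferative activity, read by MTT assay, with a stated time of 48 h (on this read-out higher numbers stand for weaker inhibition and lower numbers for stronger inhibition), compound 1 gives 46100 nM. Compound 2 `C/C(=C\CC/C(C)=C/CC[C@@H]1[C@@]2(C)CCC(=O)C(C)(C)[C@H]2CC[C@@]1(C)O)CC/C=C(\C)C(=O)OCc1cn(-c2ccccc2C(F)(F)F)nn1` replaces the propargyl group by a triazolylmethyl ester bearing 2-(trifluoromethyl)phenyl on an aromatic nitrogen. In this assay compound 2 reaches only the limit of the assay, > 150000 nM, and not a number. Compound 3 `COc1cccc(-n2cc(COC(=O)/C(C)=C/CC/C(C)=C/CC/C(C)=C/CC[C@@H]3[C@@]4(C)CCC(=O)C(C)(C)[C@H]4CC[C@@]3(C)O)nn2)c1` has 3-methoxyphenyl in that position. In this assay compound 3 likewise sits at the limit, > 150000 nM. The step that the two limits leave unreadable from compound 2 to compound 3 therefore cannot be read, because the limit of > 150000 nM in this assay, at which 2 of the 3 values shown sit, holds both ends of it.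

Compound 4 `C/C(=C\CC/C(C)=C/CC[C@@H]1[C@@]2(C)CCC(=O)C(C)(C)[C@H]2CC[C@@]1(C)O)CC/C=C(\C)C(=O)OCc1cn(-c2cccc(F)c2)nn1` is the next member of the triazole set. Its change from compound 2 is 3-fluorophenyl in place of 2-(trifluoromethyl)phenyl on an aromatic nitrogen. Among the compounds with values here, the only step bearing on this position is the unreadable one from compound 2 to compound 3, so no size can be drawn from it; the two triazole aryl variants measured both lie at the limit. Compound 4 is therefore expected to sit near the limit as well, with the step that the limit leaves unreadable from compound 2 to compound 4 expected to be none beyond the scatter. The estimate for compound 4 in this assay is 200000 nM, ranging from 80000 nM to 500000 nM.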

Compound 4, half-maximal inhibitory concentration: > 150000 nM
Compound 4 ended at the assay's limit (the forecaster's own chance of this, stated with the estimate: 70%); the middle value is on the limit's open side.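

In this assay compound 4, with 3-fluorophenyl on the aromatic nitrogen, gives > 150000 nM, a limit of the assay and not a number. This yields the first readable size for exchanging the ethynyl end of the parent ester for an aryl triazole, an at least 3.2-fold higher number from compound 1 to compound 4 (0.51 log units; beyond the scatter), which marks the exchange as a loss of activity beyond the scatter, at least for this aryl group. The steps among compound 2, compound 3 and compound 4 cannot be read, because all of them end at one limit: the limit of > 150000 nM in this assay, at which 3 of the 4 values shown sit.

Open, going by these compounds, is whether an amine or a carboxylic acid on the phenyl ring, or a longer chain in place of that ring, would return a number in this assay. Also open, on these data alone, is how far compound 2, compound 3 and compound 4 lie past the limit, and whether they differ at all.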